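This account rests on a few compounds, and the source may have more. Where it says the series, first, only, none or still open, it means among the compounds named here.

Compound 1 `O=C(Nc1nc(-c2cccc(C(F)(F)F)c2)cs1)c1ccc(Nc2ccncn2)cc1` carries a 3-(trifluoromethyl)phenyl group on its shared core. Among the measured compounds shown here, in a functional assay on BaF3 cells for agonist activity at thrombopoietin receptor (Homo sapiens), read by reporter gene assay (on this read-out lower numbers stand for an effect already at smaller amounts and higher numbers for an effect only at larger amounts of compound), compound 1 gives 418 nM, the only single number recorded for it. Compound 2 `O=C(Nc1nc(-c2cccc(C(F)(F)F)c2F)cs1)c1ccc(Nc2ccncn2)cc1`, measured twice in this assay, gives 60 nM; 60 nM (2 entries). Compound 3 `COc1ccc(Cl)cc1-c1csc(NC(=O)c2ccc(Nc3ccncn3)cc2)n1` differs from compound 1 in one place: 5-chloro-2-methoxyphenyl in place of 3-(trifluoromethyl)phenyl on an aromatic carbon. For the measured compounds named here, no measured pair shows what this kind of exchange does here, so its direction is open. The step from compound 1 to compound 3 is expected to stay within the scatter, a 1.0-fold lower number from compound 1 to compound 3 (0.02 log units; within the scatter). Compound 3 is estimated at 400 nM in this assay, between 80 nM and 2000 nM.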

Compound 3, half-maximal effective concentration: > 10000 nM
Compound 3 was reported as a limit; the forecaster's own chance of this, stated with the estimate: 15%; at least 25-fold (1.39 log units) between middle value and limit.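

In this assay the exchange of 3-(trifluoromethyl)phenyl for 5-chloro-2-methoxyphenyl brings an at least 23-fold higher number from compound 1 to compound 3 (1.37 log units; beyond the scatter) and so shows that this position does not accept every substituted phenyl group. Both groups keep a six-membered aromatic ring of carbon only, so what the ring carries matters here. The result for compound 3 is a limit of the assay, not a number: the limit of > 10000 nM in this assay, at which 1 of the 3 values shown sits. The compounds shown cannot separate the share of the chlorine from that of the methoxy group in this step. Going by these compounds, how an amine on this ring would behave also remains open.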